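The compounds below may be only part of what the source reports. "The series", "measured", "known", "first", "only" and "open" are said of these compounds alone.

Compound 3 `CS(=O)(=O)c1ccc(C(=O)Nc2ccc(Cl)c(-c3nnc4c(Cl)cccn34)c2)cc1` stands at the edge of what the assay reports: in a functional assay on U-251 cells (Homo sapiens) for antiproliferative activity, read by MTT assay, with a stated time of 72 h (a lower number here means a stronger inhibitor, a higher number a weaker inhibitor), compound 3 gives > 100000 nM, a limit rather than a number. Compound 1 `O=C(Nc1ccc(Cl)c(-c2nnc3c(Cl)cccn23)c1)c1ccc(F)cc1Cl` likewise gives a limit; in this assay compound 1 gives > 100000 nM. Compound 2 `O=C(Nc1ccc(Cl)c(-c2nnc3c(Cl)cccn23)c1)c1ccccn1` gives a number: in this assay compound 2 gives 79000 nM. Two of the three values shown sit at that limit (the limit of > 100000 nM in this assay, at which 2 of the 3 values shown sit). Compound 4 `O=C(Nc1ccc(Cl)c(-c2nnc3c(Cl)cccn23)c1)c1ccon1` differs from compound 3 by 1,2-oxazol-3-yl in place of 4-(methylsulfonyl)phenyl on a carbonyl carbon. All three measured steps swap the group on that carbonyl carbon: an at least 1.2-fold lower number from compound 1 to compound 2 (0.10 log units; that floor lies within the scatter), an at least 1.2-fold higher number from compound 2 to compound 3 (0.10 log units; that floor lies within the scatter), and a step that the two limits leave unreadable from compound 1 to compound 3. None is readable beyond the scatter, so no step beyond the scatter is expected for compound 4. Compound 4 is estimated at 100000 nM, between 40000 nM and 300000 nM, an expected step of a number no higher from compound 3 to compound 4 (the limit leaves the size open).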

Compound 4, half-maximal inhibitory concentration: > 100000 nM
Compound 4: only a limit was reported (the forecaster's own chance of this, stated with the estimate: 55%); the middle value lies on the limit itself.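

In this assay, compound 4 also gives only a limit, so a five-membered aromatic ring on this carbonyl carbon, with far fewer heavy atoms than 4-(methylsulfonyl)phenyl, does not yield a readable value. For the compounds shown here, the one step that can be read is an at least 1.2-fold higher number from compound 2 to compound 4 (0.10 log units; that floor lies within the scatter), and the steps from compound 1 and compound 3 cannot be read. The limit now holds most of this small series: the limit of > 100000 nM in this assay, at which 3 of the 4 values shown sit.

From the compounds shown here alone, it remains open whether any group at this position can move the value beyond the scatter. A group carrying an amine or a carboxylic acid would test this.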